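The source may report more compounds than this note shows. Statements on the series, on what has been measured and on what is new or still open speak of the compounds shown alone.

Measured compounds:
Compound 1 `O=C1CC(c2ccccc2F)C(=O)N1CN1CCN(c2ccccc2)CC1` — in a functional assay on the whole organism (strain CF-1 albino) with Mus musculus as the target, with a stated time of 4 h (a lower number here means that less compound is needed, a higher number that more compound is needed for the effect), compound 1 gives 300 mg/kg.
Compound 2 `O=C1CC(c2ccccc2Br)C(=O)N1CN1CCN(c2ccccc2)CC1` — compound 2 gives 100 mg/kg.
Compound 3 `O=C1CC(c2ccccc2Br)C(=O)N1CN1CCN(c2cccc(C(F)(F)F)c2)CC1` — compound 3 gives 300 mg/kg.

Compound 1 stands level with compound 3 at the digits shown, the two together giving the highest numbers of the three; its nearest neighbour is compound 3, with no change at the digits shown, and its furthest is compound 2, which gives a number lower by a 3.0-fold lower number from compound 1 to compound 2 (0.48 log units; beyond the scatter) through bromo in place of fluoro on an aromatic carbon.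

The unmeasured compound 4 `O=C1CC(c2ccccc2F)C(=O)N1CN1CCN(c2ncccn2)CC1` differs from compound 1 in one place: pyrimidin-2-yl in place of phenyl on an amine nitrogen in a ring. Of the two measured steps, only a 3.0-fold higher number from compound 2 to compound 3 (0.48 log units; beyond the scatter) touches the same part of the molecule, the group on the amine nitrogen in a ring, and it arose from trifluoromethyl in place of hydrogen on an aromatic carbon, not from exchanging the ring itself. Among the measured compounds shown here, no measured pair shows pyrimidin-2-yl in place of phenyl. The expectation therefore rests on little: compound 4 is expected to sit near compound 1, with a step of no change at the digits printed from compound 1 to compound 4 (within the scatter) that need not exceed the scatter. Compound 4 is estimated at 300 mg/kg, within a range from 100 mg/kg to 1000 mg/kg.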

Compound 4, minimum effective dose: 100 mg/kg
Compound 4: the middle estimate sits 3.0-fold (0.48 log units) above what was measured; measured number inside the range.
By their numbers in this assay, from the lowest: compounds 2 and 4 (each within the scatter of the next); then compounds 1 and 3 (each within the scatter of the next).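

In this assay, exchanging the ring on the amine nitrogen itself shifts the dose needed, with a 3.0-fold lower number from compound 1 to compound 4 (0.48 log units; beyond the scatter) for pyrimidin-2-yl in place of phenyl. Among the compounds shown here, the only earlier change at this group, trifluoromethyl added to the phenyl ring, gave a 3.0-fold higher number from compound 2 to compound 3 (0.48 log units; beyond the scatter) in the opposite direction, so this position has now moved the number both ways, though each step was read with a different halogen on the other aromatic ring. Nothing measured here accounts for the step from phenyl to pyrimidin-2-yl.

As far as these compounds go, it remains open whether the same ring exchange would lower the number when bromo stands in place of fluoro. From the compounds shown here alone, it is also open how a pyridin-2-yl ring or a plain methyl group on that amine nitrogen would compare with phenyl and pyrimidin-2-yl.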